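Trifluoromethylphenyl position shift on the shared core

The compounds below may be only part of what the source reports. "The series", "measured", "known", "first", "only" and "open" are said of these compounds alone.

Compound 3 `Oc1ccc(-c2cc(-c3ccccc3C(F)(F)F)cc(-c3ccc(O)cc3)n2)cc1` reaches only the limit of a functional assay on HCT-15 cells (Homo sapiens) for inhibition (on this read-out higher numbers stand for weaker inhibition and lower numbers for stronger inhibition), where compound 3 gives > 50000 nM. Compound 1 `Oc1ccc(-c2cc(-c3ccc(F)cc3)cc(-c3ccc(O)cc3)n2)cc1` gives 4970 nM in this assay. Compound 2 `Oc1ccc(-c2cc(-c3cccc(C(F)(F)F)c3)cc(-c3ccccc3O)n2)cc1` likewise reaches only a limit, giving > 50000 nM. Compound 4 `Oc1ccc(-c2cc(-c3cccc(C(F)(F)F)c3)cc(-c3ccc(O)cc3)n2)cc1` differs from compound 3 by 3-(trifluoromethyl)phenyl in place of 2-(trifluoromethyl)phenyl on an aromatic carbon. Among the measured compounds shown here, the one measured step that bears on this is an at least 10-fold higher number from compound 1 to compound 3 (1.00 log units; beyond the scatter), which carried compound 3 to the limit of > 50000 nM in this assay, at which 2 of the 3 values shown sit, so the size of any further change cannot be read from it. Compound 2, which also carries the 3-(trifluoromethyl)phenyl group, sits at a limit as well. For compound 4 the expected step is an at least 1.2-fold lower number from compound 3 to compound 4 (0.09 log units; that floor lies within the scatter), and its estimated value is 40000 nM with a range of 8000 nM to 100000 nM.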

Compound 4, half-maximal inhibitory concentration: > 50000 nM
Compound 4: no number, only a limit; the forecaster's own chance of this, stated with the estimate: 60%; middle value at least 1.2-fold (0.09 log units) from the limit.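

In this assay compound 4 gives > 50000 nM, a limit and not a number. With 3-(trifluoromethyl)phenyl at this position, the series shows an at least 10-fold higher number from compound 1 to compound 4 (1.00 log units; beyond the scatter), so moving the trifluoromethyl group from the 2- to the 3-position of the phenyl ring recovers no measurable inhibition. The steps to compound 4 from compound 3 and from compound 2 cannot be read, because both ends of each sit at the limit: the limit of > 50000 nM in this assay, at which 3 of the 4 values shown sit.

On these data alone, whether the two trifluoromethylphenyl isomers differ at all stays open, and so does any ranking among the limit compounds. As far as these compounds go, how 4-(trifluoromethyl)phenyl, or a phenyl ring carrying an amine or a carboxylic acid, would read at this position also stays open.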